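The compounds below may be only part of what the source reports. "The series", "measured", "known", "first", "only" and "open" are said of these compounds alone.

Measured so far: compound 1 `O=C(Nc1ccccc1[N+](=O)[O-])c1ccc(/N=N\c2c[nH]c3ccccc23)cc1` gives 208000 nM in a functional assay on HCT-116 cells (Homo sapiens) for inhibition, read by MTT assay, with a stated time of 72 h; a higher number here means a weaker inhibitor, a lower number a stronger inhibitor; compound 2 `Cc1ccccc1NC(=O)c1ccc(/N=N\c2c[nH]c3ccccc23)cc1` gives 509000 nM; compound 3 `Cc1cccc(NC(=O)c2ccc(/N=N\c3c[nH]c4ccccc34)cc2)c1` gives 98900 nM.

Compound 2 and compound 1 differ by nitro in place of methyl on an aromatic carbon, and in this assay that change gave a 2.4-fold lower number from compound 2 to compound 1 (0.39 log units; beyond the scatter). Compound 3 differs from compound 2 in the core itself, (3-methylphenyl in place of 2-methylphenyl on an amide-type nitrogen), with a 5.1-fold lower number from compound 2 to compound 3 (0.71 log units; beyond the scatter), and it also stands apart from compound 1 by a 2.1-fold lower number from compound 1 to compound 3 (0.32 log units; beyond the scatter), so compound 3 holds the lowest of the three numbers.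

Compound 4 `O=C(Nc1cccc([N+](=O)[O-])c1)c1ccc(/N=N\c2c[nH]c3ccccc23)cc1` has not yet been measured. It differs from compound 3 by nitro in place of methyl on an aromatic carbon. Going by the values given here, this is the same kind of change as the one from compound 2 to compound 1, not the same one: there the entering group sat ortho to a large group, here it sits meta to a large group.

Among the compounds with values here, the step from compound 3 to compound 4 is expected to be a 2.2-fold lower number from compound 3 to compound 4 (0.34 log units; beyond the scatter), resting on compound 2 and compound 1 because a 2.4-fold lower number from compound 2 to compound 1 (0.39 log units; beyond the scatter) is the only measured instance of this kind of change. Compound 4 is therefore estimated at 45000 nM, with a plausible range from 15000 nM to 150000 nM.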

Compound 4, half-maximal inhibitory concentration: 70100 nM
The estimate for compound 4 lay 1.6-fold (0.19 log units) below the measured number; low and high end bracket the measured number.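

In this assay, nitro in place of methyl on the second core gave a 1.4-fold lower number from compound 3 to compound 4 (0.15 log units; within the scatter), and the two instances of this change do not differ beyond the scatter: the same change on two cores in this assay, a 2.4-fold lower number (0.39 log units; beyond the scatter) from compound 2 to compound 1 and a 1.4-fold lower number (0.15 log units; within the scatter) from compound 3 to compound 4, 1.7-fold (0.24 log units) apart, within the scatter of two such steps. The change therefore carried from one core to the other without a detectable difference in size, but only two instances exist, and since one of them lies within the scatter, they do not show that nitro lowers the number on every core in this series. The 3-nitrophenyl group of compound 4 also stands clearly apart from both compounds carrying a 2-substituted ring, with a 7.3-fold lower number from compound 2 to compound 4 (0.86 log units; beyond the scatter) and a 3.0-fold lower number from compound 1 to compound 4 (0.47 log units; beyond the scatter).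

The compounds shown leave open whether other groups on this ring, such as an amine, a carboxylic acid or a methoxy group, would follow methyl and nitro or depart from them. They also leave open whether these small steps would hold on a core with a changed amide or azo link.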